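Cytotoxicity notes: aryl oxadiazole series on macrophage cells

The source may hold more compounds than are shown below. What is called first, only, known or untested is meant among the compounds shown, and "the series" means these compounds.

Measured so far:
- compound 1, `C#CCN(c1nc(-c2cccc(Br)c2)no1)C1CCCCC1`: 31.8 ug/mL
- compound 2, `CC(=O)OC[C@H]1O[C@H](OC[C@H](Cn2cc(COc3ccc(-c4noc(C)n4)cc3)nn2)OC(C)=O)C=C[C@@H]1OC(C)=O`: 112 ug/mL
- compound 3, `CC(=O)OC[C@H]1O[C@H](OC[C@@H](Cn2cc(CN(c3nc(-c4cccc([N+](=O)[O-])c4)no3)C3CCCCC3)nn2)OC(C)=O)C=C[C@@H]1OC(C)=O`: 100 ug/mL

In an ADME assay on RAW264.7 cells (Mus musculus) for cytotoxicity, read by MTT assay, with a stated time of 48 h (on this read-out higher numbers stand for lower toxicity in this test and lower numbers for higher toxicity in this test), compound 3 gives 100 ug/mL, the second highest of the three numbers. Its nearest neighbour is compound 2, whose value lies within the usual scatter of that of compound 3, so no order between these two can be claimed. Compound 1 gives the lowest number, and the gap from compound 3 to compound 1 is beyond the scatter; the two structures differ in more than one place, so no single change can be tied to it.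

Compound 4, `CC(=O)OC[C@H]1O[C@H](OC[C@@H](Cn2cc(CN(c3nc(-c4ccc(Cl)cc4)no3)C3CCCCC3)nn2)OC(C)=O)C=C[C@@H]1OC(C)=O`, has not yet been measured. It differs from compound 3 by 4-chlorophenyl in place of 3-nitrophenyl on an aromatic carbon. Going by the values given here, no measured pair in this set shows this change alone, so there is no step to draw on. The expectation for the step from compound 3 to compound 4 is a change in this assay of no more than the scatter in either direction, that is a 1.1-fold lower number from compound 3 to compound 4 (0.02 log units; within the scatter). Compound 4 is therefore estimated at 95 ug/mL, with a range from 45 ug/mL to 190 ug/mL.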

Compound 4, half-maximal cytotoxic concentration: 35.5 ug/mL
For compound 4 the middle estimate is 2.7-fold (0.43 log units) above the measured one; measured number outside the range, below it.
By their numbers in this assay, from the lowest: compounds 1 and 4 (each within the scatter of the next); then compounds 3 and 2 (each within the scatter of the next).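

At the aromatic carbon between two ring nitrogen atoms, the aryl group matters in this assay with the rest of the structure held fixed: 4-chlorophenyl in place of 3-nitrophenyl gives a 2.8-fold lower number from compound 3 to compound 4 (0.45 log units; beyond the scatter) as a step beyond the scatter. This is the first single-place comparison in the series, so this position is now shown to be open to a change in the number, with the larger sugar-bearing part of the molecule unchanged. No measurement at hand speaks to the origin of this step.

As far as these compounds go, the step swaps both the substituent and its place on the phenyl ring, and which of the two carries it stays open. Also open, from the compounds shown here alone, is how an unsubstituted phenyl or an aminophenyl at the same carbon would read in this assay on this same core.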